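From Difluorophenyl to Chlorophenyl: An Expected Potency Step

A few compounds are considered here, and "the series" means these few. Any claim that something is new, unique, unknown or untested is made for them only; others in the source may bear on it.

Of the compounds shown here, three sharing one core have been measured in a functional assay on HT-29 cells (Homo sapiens) for cytotoxicity, read by MTT assay, with a stated time of 72 h; on this read-out lower numbers stand for stronger inhibition and higher numbers for weaker inhibition. Compound 1 `COc1cc2c(Oc3ccc(NC(=O)N/N=C/c4ccc(O)cc4)cc3F)ccnc2cc1OCCCN1CCCCC1` gives 470 nM. Compound 2 `COc1cc2c(Oc3ccc(NC(=S)N/N=C/c4ccccc4)cc3F)ccnc2cc1OCCCN1CCCCC1` gives 210 nM, reached through a 2.2-fold lower number from compound 1 to compound 2 (0.35 log units; beyond the scatter). Compound 3 `COc1cc2c(Oc3ccc(NC(=S)N/N=C/c4ccc(F)c(F)c4)cc3F)ccnc2cc1OCCCN1CCCCC1` gives 610 nM, the highest of the three numbers, reached through a 2.9-fold higher number from compound 2 to compound 3 (0.46 log units; beyond the scatter); its gap to compound 1 is within the scatter, its gap to compound 2 beyond it.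

Compound 4 `COc1cc2c(Oc3ccc(NC(=S)N/N=C/c4ccc(Cl)cc4)cc3F)ccnc2cc1OCCCN1CCCCC1` is not yet measured. It differs from compound 3 by 4-chlorophenyl in place of 3,4-difluorophenyl on a carbon with a double bond to nitrogen. For the measured compounds named here, the only measured step that bears on this change is a 2.9-fold higher number from compound 2 to compound 3 (0.46 log units; beyond the scatter), where 3,4-difluorophenyl replaced phenyl and the number rose modestly. Going by the values given here, no measured step shows a chlorinated ring here, so the direction is uncertain; a single halogen is expected to land somewhere between the outcomes for phenyl and for 3,4-difluorophenyl. Compound 4 is therefore expected to give 350 nM, within a range of 150 nM to 800 nM, meaning an expected 1.7-fold lower number from compound 3 to compound 4 (0.24 log units; within the scatter).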

Compound 4, half-maximal inhibitory concentration: 190 nM
Beside the measured number, compound 4's estimate is 1.8-fold (0.27 log units) above it, within the range that was stated.
By their numbers in this assay, from the lowest: compounds 4 and 2 (each within the scatter of the next); then compounds 1 and 3 (each within the scatter of the next).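

Replacing 3,4-difluorophenyl with 4-chlorophenyl in this assay brings a 3.2-fold lower number from compound 3 to compound 4 (0.51 log units; beyond the scatter) and shows that this ring, on a carbon with a double bond to nitrogen, responds to which halogens it carries, since the rise seen with 3,4-difluorophenyl does not recur with 4-chlorophenyl. Chloro in place of hydrogen gives only a 1.1-fold lower number from compound 2 to compound 4 (0.04 log units; within the scatter) in this assay and so matches the plain phenyl compound within the scatter. The wider exchange gives a 2.5-fold lower number from compound 1 to compound 4 (0.39 log units; beyond the scatter) in this assay but alters more than one part of the group, so it cannot be assigned to the chlorine alone. Nothing available explains why the two halogen patterns differ.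

From the compounds shown here alone, whether a single fluoro, a bromo or a methoxy on this ring would behave like the chloro remains open. So does the outcome with a ring carrying an amine or a carboxylic acid.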